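Trading the cyclopentyl of compound 1 for isopropyl

The source may hold more compounds than are shown below. What is called first, only, known or untested is meant among the compounds shown, and "the series" means these compounds.

The account starts from compound 1 `CN1CCN(c2ccc(Nc3ncc(/N=C/c4ccccc4)c(NC4CCCC4)n3)cc2)CC1`. In a functional assay on MCF7 cells (Homo sapiens) for antiproliferative activity, read by MTT assay (a lower number here means a stronger inhibitor, a higher number a weaker inhibitor), compound 1 gives > 100000 nM, which is a limit of the assay and not a number. Two relatives are measured. Compound 2 `CN1CCN(c2ccc(Nc3ncc(/N=C/c4ccc(C(F)(F)F)cc4)c(NC4CCCC4)n3)cc2)CC1` also reaches only a limit, giving > 100000 nM in this assay. Compound 3 `NS(=O)(=O)c1ccc(Nc2ncc(/N=C/c3ccccc3)c(NC3CCCC3)n2)cc1` gives 39100 nM in this assay. Among the measured compounds shown here, the step that the two limits leave unreadable from compound 1 to compound 2, and the step of an at least 2.5-fold lower number from compound 1 to compound 3 (0.40 log units; beyond the scatter); the latter is the one readable step, and the limit of > 100000 nM in this assay, at which 2 of the 3 values shown sit, covers the rest. Compound 4 `CC(C)Nc1nc(Nc2ccc(N3CCN(C)CC3)cc2)ncc1/N=C/c1ccccc1` is not yet measured. Relative to compound 1 the change is isopropyl in place of cyclopentyl on a nitrogen on an aromatic ring. Neither measured step touches the cyclopentylamino side of the core, so none bears on this change. With compound 1 sitting at a limit, compound 4 is expected to stay near it, with the step of a number no higher from compound 1 to compound 4 (the limit leaves the size open) estimated as none beyond the scatter. Compound 4 is therefore expected at about 100000 nM, in the range 30000 nM to 300000 nM, and most probably reported again as a limit.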

Compound 4, half-maximal inhibitory concentration: > 100000 nM
Compound 4: no number, only a limit (the forecaster's own chance of this, stated with the estimate: 80%); the middle value lies on the limit itself.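

In this assay compound 4 gives > 100000 nM as a limit of the assay and not a number. Among the compounds shown here, compound 1 also sits at a limit, so no step between compound 1 and compound 4 can be read: the limit of > 100000 nM in this assay, at which 3 of the 4 values shown sit. The compounds shown leave open whether isopropyl in place of cyclopentyl changes the antiproliferative activity at all.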